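Swapping the dichlorophenyl of compound 1 for methoxyphenyl

A few compounds are considered here, and "the series" means these few. Any claim that something is new, unique, unknown or untested is made for them only; others in the source may bear on it.

Measured so far in a functional assay on the whole organism (artery, strain albino) with Rattus norvegicus as the target, with a stated time of 180 min, at a dose of 10 mg/kg by the oral route; a higher number here means more inhibition at the dose given (going by the name of the read-out), a lower number less inhibition:
compound 1 `CC1=C(C(=O)Nc2ccc(Br)cc2)C(c2ccc(Cl)cc2Cl)N=C(SCc2ccccc2)N1`, 13.4%
compound 2 `CC1=C(C(=O)Nc2ccc(Br)cc2)C(c2ccc(Cl)cc2Cl)N=C(SCc2cccc(Cl)c2)N1`, 11.9%
compound 3 `CC1=C(C(=O)Nc2ccc(Br)cc2)C(c2ccc(Cl)cc2Cl)N=C(SCc2ccc(F)cc2)N1`, 28.4%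

Compound 1 stands second of the three; compound 2 lies close to it, a number 1.5 percentage points lower from compound 1 to compound 2 (within the scatter), while compound 3 sits farther off, a number 15 percentage points higher from compound 1 to compound 3 (beyond the scatter). Compound 4 `COc1ccc(C2N=C(SCc3ccccc3)NC(C)=C2C(=O)Nc2ccc(Br)cc2)cc1` is not yet measured. It differs from compound 1 at a different site: 4-methoxyphenyl in place of 2,4-dichlorophenyl on a saturated ring carbon. Within the data shown here, the measured steps all concern the ring carried on a saturated chain carbon bound to a sulfur, for instance a number 16.5 percentage points higher from compound 2 to compound 3 (beyond the scatter); none touches the saturated ring carbon, so no step bears on this change. The expectation therefore rests on compound 1 alone, with no change beyond the scatter foreseen. Compound 4 is expected to give 14%, within 2% to 30%, that is a number 0.6 percentage points higher from compound 1 to compound 4 (within the scatter).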

Compound 4, a percentage reported as inhibition, in the whole organism at one dose (the size of the read-out at that dose, not a potency): 10.3%
The estimate for compound 4 lay 3.7 percentage points above the measured number, within the range that was stated.
By their numbers in this assay, from the lowest: compounds 4, 2 and 1 (each within the scatter of the next); then compound 3.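

In this assay, among these compounds, this is the first change at the saturated ring carbon, and 4-methoxyphenyl in place of 2,4-dichlorophenyl gives a number 3.1 percentage points lower from compound 1 to compound 4 (within the scatter). With the benzylsulfanyl group held fixed, this exchange therefore removes both chlorine atoms and adds a hydrogen-bond acceptor without moving the number beyond the scatter. Nothing available explains this outcome.

Going by these compounds, it remains open whether a hydroxyl or dimethylamino group on that phenyl ring would shift the number. Also open, on these data alone, is whether the 4-fluorophenyl of compound 3 would retain its effect alongside 4-methoxyphenyl.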